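From chloromethyl to 1-chloroethyl on the shared core

A few compounds are considered here, and "the series" means these few. Any claim that something is new, unique, unknown or untested is made for them only; others in the source may bear on it.

In a functional assay for inhibition, with Homo sapiens as the target (a lower number here means that less compound is needed, a higher number that more compound is needed for the effect), compound 1 (`CC1CC(c2ccc(N)cc2)=NNC1=O`) gives 43.8 ug/mL and compound 2 (`CC(=O)Nc1ccc(C2=NNC(=O)C(C)C2)cc1`) gives 46.4 ug/mL while compound 3 (`CC1CC(c2ccc(NC(=O)CCl)cc2)=NNC1=O`) gives 21.9 ug/mL on the same scale. Compound 3 lies clear of compound 2 only, with a 2.1-fold lower number from compound 2 to compound 3 (0.33 log units; beyond the scatter) as a modest step, while a 2.0-fold lower number from compound 1 to compound 3 (0.30 log units; within the scatter) stays inside the scatter. Compound 4 (`CC(Cl)C(=O)Nc1ccc(C2=NNC(=O)C(C)C2)cc1`) carries methyl in place of hydrogen on a saturated chain carbon bound to a carbonyl carbon and a chlorine atom. Going by the values given here, no measured step adds a methyl there. The nearest evidence is the modest chloro step on that chain carbon, alongside a 1.1-fold higher number from compound 1 to compound 2 (0.03 log units; within the scatter) for the acetyl group. A shift beyond the scatter is therefore not expected in this assay here. The expected step is a 1.1-fold higher number from compound 3 to compound 4 (0.04 log units; within the scatter) and it stays small. For compound 4 the estimated value is 24 ug/mL (range 11 ug/mL to 50 ug/mL).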

Compound 4, half-maximal effective concentration: 32.9 ug/mL
The estimate for compound 4 lay 1.4-fold (0.14 log units) below the measured number; the range from low to high includes it.
By their numbers in this assay, from the lowest: compounds 3, 4, 1 and 2 (each within the scatter of the next, the first and the last beyond it).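

In this assay, methyl on the saturated chain carbon bound to a carbonyl carbon and a chlorine atom changes little, with a 1.5-fold higher number from compound 3 to compound 4 (0.18 log units; within the scatter). Unlike the chloromethyl of compound 3, which cleared compound 2, the 1-chloroethyl group separates from neither comparison compound, with a 1.4-fold lower number from compound 2 to compound 4 (0.15 log units; within the scatter) and a 1.3-fold lower number from compound 1 to compound 4 (0.12 log units; within the scatter). No measurement bears on what lies behind these small steps.

Still open, as far as these compounds go, is whether a longer chain on that carbon, or an amine in place of its chlorine, would move the number beyond the scatter.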